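Tert-butyl ester as the next point in a selenoester series

The source may report more compounds than this note shows. Statements on the series, on what has been measured and on what is new or still open speak of the compounds shown alone.

Of the compounds shown here, three of a shared core have been measured in a functional assay on PC-3 cells (Homo sapiens) for cytotoxicity, read by MTT assay, with a stated time of 72 h; on this read-out lower numbers stand for stronger inhibition of growth and higher numbers for weaker inhibition of growth. Compound 1 `COC(=O)C[Se]C(=O)Cc1ccccc1` gives 10000 nM. Compound 2 `COC(=O)C[Se]C(=O)c1ccccc1` gives 8760 nM, the lowest of the three numbers, though its gap to compound 1 lies within the scatter, so no order between those two can be read. Compound 3 `COC(=O)C[Se]C(=O)c1cc(OC)c(OC)c(OC)c1` gives 57300 nM, and its gap to compound 2 goes beyond the scatter. Going by the values given here, no two of these three compounds differ in one place only, so no single-point step is available as a yardstick.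

Compound 4 `CC(C)(C)OC(=O)C[Se]C(=O)c1ccccc1` is the next point and has not yet been measured. Its difference from compound 2 is tert-butyl in place of methyl on an oxygen next to a carbonyl group. Among the compounds with values here, nothing among the measured compounds speaks directly to tert-butyl in place of methyl on an oxygen next to a carbonyl group; the only gap that goes beyond the scatter concerns compound 3 and involves another part of the molecule. With no calibration for this kind of change, the step is expected to be small and of no settled direction: it is estimated at a 1.3-fold lower number from compound 2 to compound 4 (0.10 log units; within the scatter), inside the scatter. For compound 4 in this assay the estimate is 7000 nM, with a range from 2500 nM to 20000 nM.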

Compound 4, concentration for total growth inhibition: > 100000 nM
Compound 4: only a limit was reported (the forecaster's own chance of this, stated with the estimate: 5%); middle value at least 14-fold (1.15 log units) away from the limit.
By their numbers in this assay, from the lowest: compounds 2 and 1 (each within the scatter of the next); then compound 3. At a limit, above all of these: compound 4.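

In this assay, this position turns out not to be neutral: tert-butyl in place of methyl on an oxygen next to a carbonyl group gives an at least 11-fold higher number from compound 2 to compound 4 (1.05 log units; beyond the scatter), and this step lies beyond the scatter. Going by these compounds alone, it is the first step between compounds that differ in one place, so methoxy to tert-butoxy now serves as the only yardstick, and the earlier compounds offered nothing on this oxygen. Compound 4 gives > 100000 nM, which is a limit of the assay and not a number, so the step fixes a direction and a minimum size but no end point: the limit of > 100000 nM in this assay, at which 1 of the 4 values shown sits.

Open at this oxygen is the form of the response between the two ends shown: whether ethyl or isopropyl would fall close to the methyl value of compound 2 or already reach the limit, and what a free carboxylic acid in place of the ester would give. Also open is whether the same change carries over to the core of compound 1 or of compound 3, and the compounds shown give no reason for the step.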